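Cytotoxicity notes on the shared core series

This account rests on a few compounds, and the source may have more. Where it says the series, first, only, none or still open, it means among the compounds named here.

Values in an ADME assay on Huh-7 cells (Homo sapiens) for cytotoxicity, read by MTT assay, with a stated time of 72 h (a higher number here means that more compound is tolerated, a lower number that less compound is tolerated), each a limit of the assay:
compound 1 `NC(=O)c1sc2nc(-c3ccccc3)cc(C(F)(F)F)c2c1N`: > 20000 nM
compound 2 `CCOC(=O)c1sc2nc(C3CC3)cc(C(F)(F)F)c2c1N`: > 20000 nM
compound 3 `COc1ccccc1-c1cc(C(F)(F)F)c2c(N)c(C(N)=O)sc2n1`: > 20000 nM

For compound 3 only a limit is known in this assay, and the two other values shown are limits as well (the limit of > 20000 nM in this assay, at which 3 of the 3 values shown sit). The step that the two limits leave unreadable from compound 1 to compound 3 is therefore unreadable. Compound 4 `NC(=O)c1sc2nc(C3CC3)cc(C(F)(F)F)c2c1N` differs from compound 3 by cyclopropyl in place of 2-methoxyphenyl on an aromatic carbon. Compound 2, which already carries cyclopropyl, sits at the limit in this assay. Within the data shown here, no measured step reads beyond the scatter, so no step beyond the scatter is expected from compound 3 to compound 4, estimated as a step that the limit leaves unreadable from compound 3 to compound 4. Compound 4 is expected to give 40000 nM in this assay, within 20000 nM to 100000 nM, most likely again reported only as a limit.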

Compound 4, half-maximal cytotoxic concentration: > 20000 nM
Compound 4 gave a limit, no number (the forecaster's own chance of this, stated with the estimate: 85%); the middle value does not contradict the limit.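

No step from compound 1, compound 2 or compound 3 to compound 4 can be read in this assay, because every value shown is a limit: the limit of > 20000 nM in this assay, at which 4 of the 4 values shown sit.

The compounds shown leave open at what concentration any of them becomes cytotoxic.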